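A few compounds are considered here, and "the series" means these few. Any claim that something is new, unique, unknown or untested is made for them only; others in the source may bear on it.

Working notes on the series in an ADME assay on cells for inhibition of cytochrome P450 11B1, mitochondrial (Homo sapiens), read by HTRF; a higher number here means a weaker inhibitor, a lower number a stronger inhibitor.

Compound 1 `Cc1cc(Cl)ccc1C(=O)N(C)c1cccnc1` is the smallest member; in this assay compound 1 reaches only the limit > 3000 nM, which is a limit and not a number. Compound 2 `CC(=O)N[C@@H]1CCCc2c1cncc2N1C(=O)c2ccc(Cl)cc2[C@@H]1C1CC1` and compound 3 `CC(=O)N[C@@H]1CCCc2c1cncc2N1C(=O)c2ccc(Cl)cc2[C@H]1C1CC1` share the full fused core and differ only in configuration as drawn. For compound 2 this assay again gives only a limit, > 30000 nM. Compound 3 gives 22800 nM. The step of an at least 1.3-fold lower number from compound 2 to compound 3 (0.11 log units; that floor lies within the scatter) is therefore small, and since compound 2 stands at a limit, the pair shows no clear difference (the limit of > 30000 nM in this assay, at which 1 of the 3 values shown sits, (the fact that compounds 2 and 3 differ only in the configuration as drawn)). Compound 2 thus stands at the weak end of the numbers shown, with no finite value.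

Compound 4 `CC[C@H]1c2cc(Cl)ccc2C(=O)N1c1cncc2c1CCC[C@H]2NC(C)=O` follows from compound 2 by ethyl in place of cyclopropyl on a saturated ring carbon. For the measured compounds named here, no measured step tests an exchange of this kind; the only step available, from compound 2 to compound 3, lies within the scatter and concerns configuration alone. The expected step of a number no higher from compound 2 to compound 4 (the limit leaves the size open) is therefore none beyond the scatter, with a limit again likely. Compound 4 is estimated at 30000 nM, in the range 10000 nM to 100000 nM.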

Compound 4, half-maximal inhibitory concentration: 3630 nM
Compound 4: middle estimate off by 8.3-fold (0.92 log units), on the high side; the whole stated range lies above it.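

Ethyl in place of cyclopropyl on this saturated ring carbon, next to the ring nitrogen, gives in this assay an at least 8.2-fold lower number from compound 2 to compound 4 (0.91 log units; beyond the scatter). This is the only step shown beyond the scatter, whereas the earlier step, an at least 1.3-fold lower number from compound 2 to compound 3 (0.11 log units; that floor lies within the scatter), concerned configuration alone, so this place responds to the group it carries, and in this pair the open ethyl chain goes with the stronger inhibitor. The size of the step remains a floor, as compound 2 stands at a limit: the limit of > 30000 nM in this assay, at which 1 of the 4 values shown sits.

Going by these compounds, what methyl, propyl or an aminomethyl group would give on this saturated ring carbon stays open. Also open is whether configuration at this carbon counts once ethyl is in place, which the compounds shown cannot tell.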